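The compounds below may be only part of what the source reports. "The series", "measured", "known", "first", "only" and "open" are said of these compounds alone.

Only a little is known so far about this small series of compounds that share one core. Among the measured compounds shown here, in a functional assay on HCT-116 cells (Homo sapiens) for cytotoxicity (a higher number here means that more compound is needed for the effect, a lower number that less compound is needed), compound 1 (`CC(=O)SCC(=O)c1ccc(NS(=O)(=O)c2ccccc2)cc1`) gives 15400 nM, and this is the only actual number available. Compound 2 (`CC(=O)SCC(=O)c1ccc(NS(=O)(=O)c2ccccc2Cl)cc1`) has no usable result, its entry reading "not determined" (no result reported). Compound 3 (`CC(=O)SCC(=O)c1ccc(NS(=O)(=O)c2ccc(F)cc2)cc1`) is in the same position, with its entry also reading "not determined" (no result reported). Compound 3 therefore cannot be ranked against compound 1, and it offers no number to build on.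

The next compound to be tested is compound 4 (`CC(=O)SCC(=O)c1ccc(NS(=O)(=O)c2ccc(C)cc2)cc1`). The structural change is small: methyl in place of fluoro on an aromatic carbon. In words, this is methyl in place of fluoro on an aromatic carbon, so that a 4-fluorophenyl becomes a 4-methylphenyl. For the measured compounds named here, no step between two measured compounds exists, so nothing shows how much a change of this kind matters here. Going by the values given here, the expectation must therefore lean on the single value available, that of compound 1 at 15400 nM. Compound 4 is expected to land near that value, with no step beyond the usual scatter in this assay and no preferred direction. For compound 4 the estimate is 15000 nM, with an expected range from 5000 nM to 40000 nM.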

Compound 4, half-maximal effective concentration: 6500 nM
Compound 4: the middle estimate sits 2.3-fold (0.36 log units) above what was measured; the range from low to high includes it.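

In this assay, replacing a ring hydrogen with methyl gives a 2.4-fold lower number from compound 1 to compound 4 (0.37 log units; beyond the scatter). Among the compounds shown here, this is the first readable step, and it shows that this position is not silent: a change of one heavy atom, para to a large group, is enough to move the result modestly beyond the usual scatter, towards less compound being needed for the effect. The swap of fluoro for methyl cannot be read, as compound 3 has no number, and nothing available explains why the methyl step has this size or direction.

Going by these compounds, a single step cannot show whether the shift belongs to methyl in particular or would appear with other groups in the same place, so the effect of an ethyl, a methoxy or an amine there remains open. Also open, on these data alone, is how much of the activity depends on the rest of the shared core, for instance whether the acetyl group on the sulfur could be replaced by a longer chain without changing the result.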